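The source may hold more compounds than are shown below. What is called first, only, known or untested is meant among the compounds shown, and "the series" means these compounds.

Compound 1, `COc1cc(F)ccc1N1C(=O)CSC1c1cccc(C(=O)NCCCCc2ccccc2)c1`, gives 63% in a functional assay on 143B cells (Homo sapiens) for inhibition, read by CCK-8 assay, with a stated time of 72 h, tested at 1 uM; on this read-out higher numbers stand for more inhibition at the one concentration tested (going by the name of the read-out) and lower numbers for less inhibition.
Compound 2, `COc1c(F)cccc1N1C(=O)CSC1c1cccc(C(=O)NCCCCc2ccccc2)c1`, gives 5% in this assay.
Compound 3, `O=C(NCCCCc1ccccc1)c1cccc(C2SCC(=O)N2c2ccccc2F)c1`, gives 59% in this assay.

Among these three numbers compound 3 stands second highest. Its nearest neighbour is compound 1: the step of a number 4 percentage points lower from compound 1 to compound 3 (within the scatter) lies within the scatter, so the two cannot be ranked against each other. Its furthest is compound 2: the step of a number 54 percentage points higher from compound 2 to compound 3 (beyond the scatter) is large and well beyond the scatter. The other measured step, a number 58 percentage points lower from compound 1 to compound 2 (beyond the scatter), shows how sharply the read-out can fall when the substitution pattern on the aryl group at the ring nitrogen is changed.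

Compound 4, `COc1ccc(N2C(=O)CSC2c2cccc(C(=O)NCCCCc3ccccc3)c2)c(OC)c1`, differs from compound 3 in one place: 2,4-dimethoxyphenyl in place of 2-fluorophenyl on an amide-type nitrogen in a ring. Within the data shown here, no measured step introduces a 2,4-dimethoxyphenyl group, so none bears on this change directly. The closest analogy is compound 1, which also carries a methoxy group and a second substituent at the 4-position of that aryl ring and gives 63%; the step of a number 4 percentage points lower from compound 1 to compound 3 (within the scatter) suggests that such a pattern need not cost much. Compound 2 warns that the outcome can swing widely. On balance a modest decrease is expected, a number 14 percentage points lower from compound 3 to compound 4 (beyond the scatter), with wide uncertainty. Compound 4 is therefore estimated at 45%, in a range from 10% to 70%.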

Compound 4, a percentage reported as inhibition, at one concentration (the size of the read-out at that concentration, not a potency): 53%
For compound 4 the middle estimate is 8 percentage points below the measured one, and the stated range covers the measured number.
By their numbers in this assay, from the lowest: compound 2; then compounds 4, 3 and 1 (each within the scatter of the next).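

With the 2,4-dimethoxyphenyl group on the amide-type nitrogen, the read-out in this assay cannot be told apart from that of the 2-fluorophenyl analogue, as the step of a number 6 percentage points lower from compound 3 to compound 4 (within the scatter) shows, so this position accepts two methoxy groups in place of a single fluoro without a measurable change. Methoxy in place of fluoro on an aromatic carbon likewise leaves the number unresolved, with the step of a number 10 percentage points lower from compound 1 to compound 4 (within the scatter) showing no change beyond the usual variation, while the step of a number 48 percentage points higher from compound 2 to compound 4 (beyond the scatter) is large and leaves compound 2, with its 3-fluoro-2-methoxyphenyl group, as the one compound that goes against this shared level among the four aryl groups. No data are available that explain the behaviour of any of these groups at this position.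

On these data alone, whether the level in this assay would hold with an amine or a carboxylic acid on this aryl ring in place of methoxy remains open, as does the effect of a longer chain on the amide of the shared core. Since each number comes from one concentration, the compounds shown also leave open how their potencies compare.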